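From benzyl to 2-fluorobenzyl on compound 3

This account rests on a few compounds, and the source may have more. Where it says the series, first, only, none or still open, it means among the compounds named here.

Values in an ADME assay on microsomes from liver (Homo sapiens) for metabolic stability, with a stated time of 60 min, tested at 1 uM (on this read-out lower numbers stand for a less stable compound and higher numbers for a more stable compound), for the three measured compounds:
Compound 1 `CS(=O)(=O)Nc1ccc2c(c1)S(=O)(=O)N=C(C1=C(O)[C@@H]3[C@H]4CC[C@H](C4)[C@@H]3N(Cc3ccccc3)C1=O)N2` gives 80%
Compound 2 `CS(=O)(=O)Nc1ccc2c(c1)S(=O)(=O)N=C(C1=C(O)[C@@H]3[C@H]4CC[C@H](C4)[C@@H]3N(Cc3ccccc3F)C1=O)N2` gives 89%
Compound 3 `CS(=O)(=O)Nc1ccc2c(c1)S(=O)(=O)N=C(C1=C(O)[C@@H]3[C@@H]4CC[C@@H](C4)[C@@H]3N(Cc3ccccc3)C1=O)N2` gives 90%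

Compound 3 at 90% lies within the usual scatter of both other compounds, so the three cannot be ranked. Changing configuration alone gave a number 10 percentage points higher from compound 1 to compound 3 (within the scatter) and this rests on the fact that compounds 1 and 3 differ only in the configuration as drawn as the only difference between them.

Compound 4 `CS(=O)(=O)Nc1ccc2c(c1)S(=O)(=O)N=C(C1=C(O)[C@@H]3[C@@H]4CC[C@@H](C4)[C@@H]3N(Cc3ccccc3F)C1=O)N2` is compound 3 with benzyl replaced by 2-fluorobenzyl, the difference being fluoro in place of hydrogen on an aromatic carbon and no other. The same fluoro in place of hydrogen on an aromatic carbon, made in the other drawn configuration, gave a number 9 percentage points higher from compound 1 to compound 2 (within the scatter) and that is the closest measured precedent. No step beyond the scatter is therefore expected in this assay for this change. The expected change is a number 2 percentage points higher from compound 3 to compound 4 (within the scatter) and it is estimated to stay inside the scatter. Compound 4 is expected at 92% within an estimated range of 82% to 99% until it is measured.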

Compound 4, percent of the compound remaining: 83%
Compound 4: middle estimate off by 9 percentage points, on the high side, and the stated range covers the measured number.
By their numbers in this assay, from the lowest: compounds 1, 4, 2 and 3 (each within the scatter of the next).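

In this assay, the move from benzyl to 2-fluorobenzyl gave a number 7 percentage points lower from compound 3 to compound 4 (within the scatter), and a change of drawn configuration alone between the two 2-fluorobenzyl compounds gave a number 6 percentage points lower from compound 2 to compound 4 (within the scatter). Neither step can be read on its own, but taken together the outcome of placing fluoro on this aromatic carbon differs with the drawn configuration of the core, something a single pair could not show: the same change on two cores in this assay, a number 9 percentage points higher (within the scatter) from compound 1 to compound 2 and a number 7 percentage points lower (within the scatter) from compound 3 to compound 4, 16 percentage points apart, beyond the scatter of two such steps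

This reading rests on only two matched pairs, so the compounds shown leave open whether the same difference between configurations would appear with chloro or methoxy in place of fluoro on the same aromatic carbon. They also leave open how such groups would behave on the shared core in either configuration.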